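Ethyl to methyl at the inactive end of the series

This account rests on a few compounds, and the source may have more. Where it says the series, first, only, none or still open, it means among the compounds named here.

In a functional assay on MDA-MB-231 cells (Homo sapiens) for cytotoxicity, read by sulforhodamine B assay, with a stated time of 72 h (a higher number here means a weaker inhibitor, a lower number a stronger inhibitor), compound 1 `CSC(=O)c1c(O[C@@H]2O[C@H](CO)[C@@H](O)[C@H](O)[C@H]2O)c(C)c(O)c(C)c1C(C)C` gives > 40000 nM, a limit of the assay. Compound 2 `CCc1c(C)c(O)c(C)c(O[C@@H]2O[C@H](CO)[C@@H](O)[C@H](O)[C@H]2O)c1C(=O)SC` gives > 40000 nM, also a limit, so it has no numerical potency. Compound 3 `CSC(=O)c1c(C)c(C)c(O)c(C)c1O[C@@H]1O[C@H](CO)[C@@H](O)[C@H](O)[C@H]1O` differs from compound 2 by hydrogen in place of methyl on a saturated chain carbon bound to an aromatic carbon, which is ethyl to methyl. Among the measured compounds shown here, the only measured step, a step that the two limits leave unreadable from compound 1 to compound 2, makes the same exchange of hydrogen for methyl. It leaves the limit of > 40000 nM in this assay, at which 2 of the 2 values shown sit, and gives no size or direction. No step beyond the scatter is expected in this assay, and the expected step is a step that the limit leaves unreadable from compound 2 to compound 3. For compound 3 the estimate is 50000 nM, with an expected range of 25000 nM to 100000 nM.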

Compound 3, half-maximal inhibitory concentration: > 40000 nM
Compound 3 ended at the assay's limit (the forecaster's own chance of this, stated with the estimate: 90%); the middle value does not contradict the limit.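

No step can be read among compound 1, compound 2 and compound 3 in this assay, as each stands at a limit of the assay: the limit of > 40000 nM in this assay, at which 3 of the 3 values shown sit.

The compounds shown leave open whether any change at this chain gives a numerical potency.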